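A few compounds are considered here, and "the series" means these few. Any claim that something is new, unique, unknown or untested is made for them only; others in the source may bear on it.

Compound 3 `O=C(/C=C/c1ccc(O)cc1)c1c(O)cccc1OCC1CCCC1` carries a cyclopentyl group on a saturated chain carbon bound to an oxygen on an aromatic ring. In an assay on THP-1 cells for inhibition of nuclear factor NF-kappa-B complex (Homo sapiens), with stated times of 2 h and 16 h (on this read-out higher numbers stand for weaker inhibition and lower numbers for stronger inhibition), compound 3 gives 13000 nM, the highest of the two numbers recorded; its nearest neighbour is compound 1 `CC(C)(C)CCOc1cccc(O)c1C(=O)/C=C/c1ccc(O)cc1`, which gives 3000 nM, so that a 4.3-fold higher number from compound 1 to compound 3 (0.64 log units; beyond the scatter). Compound 2 `CC(C)=CCOc1cccc(O)c1C(=O)/C=C/c1ccc(O)cc1` reaches only the limit > 30000 nM in this assay. Compound 4 `CCCCOc1cccc(O)c1C(=O)/C=C/c1ccc(O)cc1` differs from compound 3 by propyl in place of cyclopentyl on a saturated chain carbon bound to an oxygen on an aromatic ring. Going by the values given here, both measured departures from neopentyl, a 4.3-fold higher number from compound 1 to compound 3 (0.64 log units; beyond the scatter) and an at least 10-fold higher number from compound 1 to compound 2 (1.00 log units; beyond the scatter), gave higher numbers, and no measured pair exchanges cyclopentyl for an unbranched chain. The expected step is a 1.5-fold higher number from compound 3 to compound 4 (0.19 log units; within the scatter), taking compound 4 to an estimated 20000 nM with a range from 8000 nM to 50000 nM.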

Compound 4, half-maximal inhibitory concentration: > 30000 nM
Compound 4 ended at the assay's limit; the forecaster's own chance of this, stated with the estimate: 30%; middle value at least 1.5-fold (0.17 log units) away from the limit.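

Propyl in place of cyclopentyl at this place gives an at least 2.3-fold higher number from compound 3 to compound 4 (0.36 log units; beyond the scatter), so the unbranched chain of compound 4 does not hold even the number of compound 3. Ethyl in place of tert-butyl gives an at least 10-fold higher number from compound 1 to compound 4 (1.00 log units; beyond the scatter), which means that all three departures from compound 1 now give higher numbers. Compound 2 and compound 4 both stand at a limit of the assay, so the step between them cannot be read: the limit of > 30000 nM in this assay, at which 2 of the 4 values shown sit.

As far as these compounds go, it remains open whether a longer chain or an amine at this place would give a lower number than compound 1.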